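The source may report more compounds than this note shows. Statements on the series, on what has been measured and on what is new or still open speak of the compounds shown alone.

Of the compounds shown here, two in this set share one core and have been measured in a functional assay on MCF7 cells (Homo sapiens) for antiproliferative activity, read by MTT assay, with a stated time of 48 h, in the presence of a further agent that is not named here; on this read-out lower numbers stand for stronger inhibition of growth and higher numbers for weaker inhibition of growth. Compound 1 `O=C(NOCc1ccccc1F)c1cn(-c2ccccc2)nc1-c1ccccc1` gives 16100 nM in this assay. Compound 2 `O=C(NOCc1ccccc1)c1cn(-c2ccccc2)nc1-c1ccc(F)cc1` gives 15300 nM in this assay, the lower of the two numbers, though the gap to compound 1 lies within the scatter of repeated measurements, so the two should be read as alike. Compound 3 `O=C(NOCc1ccccc1F)c1cn(-c2ccccc2)nc1-c1ccc(F)cc1` is the next member and has not yet been measured. It differs from compound 2 in a single place: fluoro in place of hydrogen on an aromatic carbon, on the benzyl part of the molecule. Nothing in the two measured values shows what a change of this kind does here, so no step beyond the scatter is expected in either direction. The expected step from compound 2 to compound 3 is therefore a 1.0-fold lower number from compound 2 to compound 3 (0.01 log units; within the scatter). Compound 3 is estimated at 15000 nM in this assay, with a likely range from 7000 nM to 32000 nM.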

Compound 3, concentration for 50% growth inhibition: 12000 nM
Estimate against measurement, compound 3: 1.3-fold (0.10 log units) above; the range from low to high includes it.
By their numbers in this assay, from the lowest: compounds 3, 2 and 1 (each within the scatter of the next).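

In this assay putting fluoro in place of hydrogen on the benzyl part, ortho to a large group, gives a 1.3-fold lower number from compound 2 to compound 3 (0.11 log units; within the scatter) and so does not separate 2-fluorobenzyl from benzyl at this position. Fluoro placed outside the benzyl part gives a 1.3-fold lower number from compound 1 to compound 3 (0.13 log units; within the scatter) and likewise leaves the two compounds alike. Compound 3 carries both fluoro groups yet reads as alike with the two compounds that carry one each, so neither fluoro moves the number beyond the scatter in these pairs.

On these data alone, whether a methoxy group, an amine or a carboxylic acid at this position would move the number beyond the scatter stays open, as does fluoro on the other carbons of the benzyl ring. No measurement available here bears on why these numbers stay so close.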